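Replacing a Methylcarbamoyl Phenyl with a Methoxyphenyl

A few compounds are considered here, and "the series" means these few. Any claim that something is new, unique, unknown or untested is made for them only; others in the source may bear on it.

Compound 1 `Cc1c(Cc2ccc(C(=O)O)cc2S(=O)(=O)c2ccccc2)c2c(n1CC(=O)O)CCNC2=O`: 19 nM
Compound 2 `Cc1c(Cc2ccccc2S(=O)(=O)c2cccc(Cl)c2)c2c(n1CC(=O)O)CCNC2=O`: 4 nM
Compound 3 `CNC(=O)c1cccc(S(=O)(=O)c2ccccc2Cc2c3c(n(CC(=O)O)c2C)CCNC3=O)c1`: 240 nM

In a functional assay on CHO.K1 cells for antagonist activity at prostaglandin D2 receptor 2 (Homo sapiens), read by GTPgammaS binding, with a stated time of 1 h (a higher number here means a weaker inhibitor, a lower number a stronger inhibitor), compound 3 gives the highest of the three numbers, with compound 1 closest and compound 2 furthest; the step of a 60-fold higher number from compound 2 to compound 3 (1.78 log units; beyond the scatter) is large and beyond the scatter. Compound 4 `COc1ccc(S(=O)(=O)c2ccccc2Cc2c3c(n(CC(=O)O)c2C)CCNC3=O)cc1` differs from compound 3 by 4-methoxyphenyl in place of 3-(methylcarbamoyl)phenyl on a sulfonyl sulfur. Within the data shown here, the one step that bears on this change is a 60-fold higher number from compound 2 to compound 3 (1.78 log units; beyond the scatter), where introducing the methylcarbamoyl group raised the number sharply; removing it again, though to a different group, is expected to reverse part of that. Compound 4 is therefore estimated to give a lower number, a step of a 9.6-fold lower number from compound 3 to compound 4 (0.98 log units; beyond the scatter), landing at 25 nM with a range from 6 nM to 100 nM.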

Compound 4, half-maximal inhibitory concentration: 3.9 nM
Beside the measured number, compound 4's estimate is 6.4-fold (0.81 log units) above it, outside the stated range (below it).
By their numbers in this assay, from the lowest: compounds 4 and 2 (each within the scatter of the next); then compound 1; then compound 3.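

In this assay the step of a 62-fold lower number from compound 3 to compound 4 (1.79 log units; beyond the scatter) shows that an aryl group on the sulfonyl sulfur can regain what 3-(methylcarbamoyl)phenyl lost, and the step of a 1.0-fold lower number from compound 2 to compound 4 (0.01 log units; within the scatter) puts 4-methoxyphenyl level with 3-chlorophenyl. Two different groups on this sulfur therefore give matching numbers, while only the methylcarbamoyl compound stands apart. The compounds shown leave open whether the methoxy group or its place on the ring matters, and how an amine or a carboxylic acid on this phenyl would read. No supporting measurement is available to explain the recovery.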